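A few compounds are considered here, and "the series" means these few. Any claim that something is new, unique, unknown or untested is made for them only; others in the source may bear on it.

Compound 1 `O=C(O)CN1Cc2ccc(NC(=O)CCCC3CCNCC3)cc2C1=O` gives 66000 nM in a functional assay on a cell-free system (Platelet, plasma, Homo sapiens) for inhibition (a lower number here means a stronger inhibitor, a higher number a weaker inhibitor), the highest of the two numbers recorded so far. Compound 2 `O=C(O)CCN1Cc2ccc(NC(=O)c3ccc(N4CCNCC4)cc3)cc2C1=O` gives 540 nM in this assay, a markedly lower figure, a gap well beyond the scatter. Compound 3 `CC(CC(=O)O)N1Cc2ccc(NC(=O)CCCC3CCNCC3)cc2C1=O` differs from compound 1 in one place: 1-(carboxymethyl)ethyl in place of carboxymethyl on an amide-type nitrogen in a ring. Among the compounds with values here, no step between two measured compounds of this kind is known, so the effect of the change is uncertain, and only a small shift, if any, is expected, with no clear direction beyond the scatter. For compound 3 the expected value is 45000 nM, with a likely range from 15000 nM to 130000 nM. That estimate amounts to an expected step of a 1.5-fold lower number from compound 1 to compound 3 (0.17 log units; within the scatter).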

Compound 3, half-maximal inhibitory concentration: 5400 nM
Estimate against measurement, compound 3: 8.3-fold (0.92 log units) above; measured number below the stated range.
By their numbers in this assay, from the lowest: compound 2; then compound 3; then compound 1.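

Placing 1-(carboxymethyl)ethyl instead of carboxymethyl on the amide-type nitrogen in the ring gives a 12-fold lower number from compound 1 to compound 3 (1.09 log units; beyond the scatter) in this assay, so this position responds strongly to the group it carries. The two groups have the same counts of hydrogen-bond donors and acceptors and no net charge, but the entering group has more carbon. Nothing available explains the gain. On these data alone, it remains open how a longer chain such as 3-carboxypropyl would fare on this nitrogen, and whether a methyl ester in place of the carboxylic acid would keep the gain.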